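The source may hold more compounds than are shown below. What is called first, only, known or untested is meant among the compounds shown, and "the series" means these compounds.

Compound 1, whose structure is `CCOC(=O)c1c(-c2c(Cl)c3ccccc3oc2=O)nn(-c2ccccc2)c1C(=O)OCC`, was tested in a functional assay on A549 cells (Homo sapiens) for cytotoxicity, read by MTT assay, with a stated time of 48 h (on this read-out lower numbers stand for stronger inhibition and higher numbers for weaker inhibition), and there compound 1 gives 34000 nM. Compound 2, with the structure `CCOC(=O)c1c(-c2c(Cl)c3ccccc3oc2=O)nn(-c2cccc(C)c2)c1C(=O)OCC`, carries one change relative to compound 1: methyl in place of hydrogen on an aromatic carbon. In this assay compound 2 gives 36000 nM, so that the change made the step of a 1.1-fold higher number from compound 1 to compound 2 (0.02 log units; within the scatter).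

Compound 3, whose structure is `CCOC(=O)c1c(-c2cc3ccc(OC)cc3oc2=O)nn(-c2ccccc2)c1C(=O)OCC`, rests on a different core; the difference between the two cores is not broken down here. In this assay compound 3 gives 132000 nM, the highest number of the three measured compounds.

Compound 4, with the structure `CCOC(=O)c1c(-c2cc3ccc(OC)cc3oc2=O)nn(-c2cccc(C)c2)c1C(=O)OCC`, has not been measured. It differs from compound 3 by methyl in place of hydrogen on an aromatic carbon, the same change that separates compound 2 from compound 1, at the same kind of place. Because that earlier change gave a 1.1-fold higher number from compound 1 to compound 2 (0.02 log units; within the scatter), the expected step of a 1.1-fold higher number from compound 3 to compound 4 (0.03 log units; within the scatter) is estimated to be equally small. On this basis compound 4 is expected to give about 140000 nM in this assay, most likely between 60000 nM and 300000 nM.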

Compound 4, half-maximal inhibitory concentration: 171000 nM
Compound 4: the middle estimate sits 1.2-fold (0.09 log units) below what was measured, within the range that was stated.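

In this assay, going from phenyl to 3-methylphenyl on the core of compound 3 gave a 1.3-fold higher number from compound 3 to compound 4 (0.11 log units; within the scatter), so on this core too the two numbers cannot be told apart. Set beside the earlier step, the new one does not differ from it: the same change on two cores in this assay, a 1.1-fold higher number (0.02 log units; within the scatter) from compound 1 to compound 2 and a 1.3-fold higher number (0.11 log units; within the scatter) from compound 3 to compound 4, 1.2-fold (0.09 log units) apart, within the scatter of two such steps. This shows that, in this assay, the methyl behaves alike on the two cores, but it rests on a single pair per core and on a change with no readable effect on either, so it shows only that a null result carried over, not that a real effect would carry from one core to the other.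

The compounds shown leave open whether an amine, a methoxy or a longer chain in place of this methyl would give a step beyond the scatter on either core. They also leave open what a carboxylic acid in place of an ethyl ester would do, on either core.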